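The source may hold more compounds than are shown below. What is called first, only, known or untested is meant among the compounds shown, and "the series" means these compounds.

Compound 1 `CCCCCC(=O)N1CCN(c2nnc3nncn3n2)CC1`: 5260 nM
Compound 2 `CCCNc1nnc2nncn2n1`: 19800 nM

Both were tested in a functional assay on MCF7 cells (Homo sapiens) for inhibition, read by MTT assay, with a stated time of 72 h; a higher number here means a weaker inhibitor, a lower number a stronger inhibitor. Of the two numbers, compound 1 gives the lower one, at 5260 nM, while compound 2 sits higher, at 19800 nM, a gap beyond the usual scatter. Compound 3 `CCC(=O)N1CCN(c2nnc3nncn3n2)CC1` has not yet been measured. It differs from compound 1 in one place: hydrogen in place of propyl on a saturated chain carbon, two bonds along the chain from a carbonyl carbon. For the measured compounds named here, no measured pair shows a change of this kind, so the size of the step is uncertain; a modest move toward a weaker inhibitor, or none beyond the scatter, is expected. Compound 3 is expected to give about 8000 nM in this assay, with a likely range from 2500 nM to 25000 nM. That estimate means an expected step of a 1.5-fold higher number from compound 1 to compound 3 (0.18 log units; within the scatter).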

Compound 3, half-maximal inhibitory concentration: 14800 nM
Compound 3: middle estimate off by 1.9-fold (0.27 log units), on the low side; low and high end bracket the measured number.
By their numbers in this assay, from the lowest: compound 1; then compounds 3 and 2 (each within the scatter of the next).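

In this assay, replacing propyl with hydrogen on a saturated chain carbon, two bonds along the chain from a carbonyl carbon, moves toward a weaker inhibitor (a 2.8-fold higher number from compound 1 to compound 3 (0.45 log units; beyond the scatter)). This gives the first measured size for this change and shows that the pentylcarbonyl chain of compound 1 and the propanoyl chain of compound 3 are not interchangeable here. Nothing measured here explains the step. Two chain lengths cannot define a trend. As far as these compounds go, whether a butanoyl chain would fall between them, or a longer chain or one ending in an amine would give a lower number, remains open.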